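The source may hold more compounds than are shown below. What is called first, only, known or untested is meant among the compounds shown, and "the series" means these compounds.

Compounds measured in a functional assay on EA.hy 926 cells (Homo sapiens) for cytotoxicity, read by MTT assay, with stated times of 24 h and 12 h, tested at 100 uM; a lower number here means a weaker effect, a higher number a stronger effect of the compound at the concentration tested:

compound 1, `Cc1nc(C)c(C(=O)Oc2ccccc2/C=C/C(=O)O)nc1C`, giving 80.1%
compound 2, `CCOC(=O)/C=C/c1ccc(OC(=O)c2nc(C)c(C)nc2C)c(O)c1`, giving 375%
compound 3, `CCOC(=O)/C=C/c1ccc(OC(=O)c2nc(C)c(C)nc2C)cc1`, giving 96.1%

Compound 3 stands second highest of the three. Going by the values given here, compound 1 sits nearest, a step beyond the scatter below it, while compound 2 lies far above: the only step that differs in one place, a number 278.9 percentage points lower from compound 2 to compound 3 (beyond the scatter), comes from exchanging hydroxy for hydrogen on an aromatic carbon and does not touch the ester.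

Compound 4, `Cc1nc(C)c(C(=O)Oc2ccc(/C=C/C(=O)O)cc2)nc1C`, differs from compound 3 by hydrogen in place of ethyl on an oxygen next to a carbonyl group. Among the compounds with values here, no measured step bears on this change directly. Within the data shown here, the only guide is that compound 1, which also carries a free carboxy group, gives a value close to compound 3 yet a step beyond the scatter lower; the two differ in more than one place, so only their values are compared. A small step downward, or none beyond the scatter, is therefore expected in this assay.

Compound 4 is estimated at 85%, with a range from 60% to 115%, which means an expected step of a number 11.1 percentage points lower from compound 3 to compound 4 (beyond the scatter).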

Compound 4, a percentage reported as activity, at one concentration (the size of the read-out at that concentration, not a potency): 93.2%
The estimate for compound 4 lay 8.2 percentage points below the measured number; the measured number falls inside the stated range.
By their numbers in this assay, from the lowest: compound 1; then compounds 4 and 3 (each within the scatter of the next); then compound 2.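

Exchanging ethyl for hydrogen on the oxygen next to the carbonyl group, which turns ethoxycarbonyl into carboxy, gives in this assay a step of a number 2.9 percentage points lower from compound 3 to compound 4 (within the scatter). This is the first one-place step shown at this position, and it shows that, for this pair, the ethyl group can be lost without a change beyond the scatter, whereas the only earlier step, at the hydroxy position, was large. No measurement shown offers an explanation for this result.

Going by these compounds, it remains open whether the same exchange would leave the reading unchanged in compound 2, which gives 375% and carries the hydroxy group alongside its ester. Also open, on these data alone, is how a longer chain in place of ethyl, or an amide in place of the ester, would read.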